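The source may hold more compounds than are shown below. What is called first, only, known or untested is meant among the compounds shown, and "the series" means these compounds.

Among the measured compounds shown here, compound 1 `O=C(CCCC1CCN(S(=O)(=O)Nc2ccccc2)CC1)NO` is the only compound of this set with a result, giving 2000 nM in a functional assay on HCT-116 cells (Homo sapiens) for inhibition, read by resazurin assay, with a stated time of 5 days; on this read-out higher numbers stand for weaker inhibition of growth and lower numbers for stronger inhibition of growth. Compound 2 `O=C(CCCC1CCN(S(=O)(=O)c2ccccc2O)CC1)NO` gives "not determined" (no result reported) in this assay, and compound 3 `O=C(/C=C/CC1CCN(S(=O)(=O)c2ccccc2)CC1)NO` gives "not determined" (no result reported) in this assay, so compound 1 stands alone as the point of reference. Compound 4 `O=C(CCCC1CCN(S(=O)(=O)c2ccccc2)CC1)NO` has not yet been measured in this assay. It differs from compound 1 in one place: phenyl in place of anilino on a sulfonyl sulfur. For the measured compounds named here, no step between two measured compounds is available to calibrate this change, so the expected step from compound 1 to compound 4 in this assay is a 1.3-fold lower number from compound 1 to compound 4 (0.12 log units; within the scatter), which is taken to lie within the usual scatter in either direction. On this basis compound 4 is expected to give about 1500 nM in this assay, with a plausible range from 500 nM to 5000 nM.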

Compound 4, concentration for 50% growth inhibition: 2700 nM
For compound 4 the middle estimate is 1.8-fold (0.26 log units) below the measured one; the range from low to high includes it.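

Phenyl in place of anilino on a sulfonyl sulfur gives a 1.4-fold higher number from compound 1 to compound 4 (0.13 log units; within the scatter) in this assay, the first step that can be read at this position. The hydrogen-bond donor of anilino is absent from phenyl, yet the two compounds cannot be told apart on this read-out. Nothing shown explains this result.

The compounds shown leave open whether a carboxylic acid or an aliphatic amine on the sulfonyl sulfur would move the number beyond the scatter. A single step also cannot show how far this position tolerates change.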